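Solubility notes on a cyclopentyloxy to cyclobutylmethoxy pair

The source may hold more compounds than are shown below. What is called first, only, known or untested is meant among the compounds shown, and "the series" means these compounds.

Measured so far:
compound 1, `CS(=O)(=O)c1ccc(-n2nc(C(F)(F)F)cc2OC2CCCC2)nc1` — 50 ug/mL
compound 2, `CS(=O)(=O)c1ccc(-n2nc(C(F)(F)F)cc2OC2CCCC2)cc1` — 25 ug/mL
compound 3, `CS(=O)(=O)c1ccc(-n2nc(C(F)(F)F)cc2OCC2CCC2)nc1` — 100 ug/mL

Three compounds have been run in a physicochemical assay for solubility; on this read-out higher numbers stand for higher solubility and lower numbers for lower solubility. Compound 1 and compound 2 share the same side chain but differ in the core; that difference between the two cores is not broken down here, and their values in this assay lie within the scatter of each other, so no order is claimed between them. Compound 3 carries the core of compound 1 with cyclobutylmethyl in place of cyclopentyl on an oxygen on an aromatic ring; the step of a 2.0-fold higher number from compound 1 to compound 3 (0.30 log units; within the scatter) is within the scatter and so, on its own, shows no real change.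

Compound 4, `CS(=O)(=O)c1ccc(-n2nc(C(F)(F)F)cc2OCC2CCC2)cc1`, has not been measured. It stands to compound 2 as compound 3 stands to compound 1: cyclobutylmethyl in place of cyclopentyl on an oxygen on an aromatic ring. Both place lines read the same, so this is the same change made on the other core. Among the compounds with values here, with only one measured instance of the change and that instance inside the scatter, the expectation for compound 4 can rest only on the step from compound 1 to compound 3 and on the value of compound 2.

The step from compound 2 to compound 4 is estimated at a 2.0-fold higher number from compound 2 to compound 4 (0.30 log units; within the scatter), echoing the earlier step because the pair shows a 2.0-fold higher number from compound 1 to compound 3 (0.30 log units; within the scatter). Compound 4 is therefore expected to give about 50 ug/mL in this assay, with a likely range from 25 ug/mL to 100 ug/mL.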

Compound 4, solubility: 25 ug/mL
Compound 4: middle estimate off by 2.0-fold (0.30 log units), on the high side, within the range that was stated.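

Notes on carrying the change across cores: in this assay, replacing cyclopentyl with cyclobutylmethyl on an oxygen on an aromatic ring reads (no change at the digits printed from compound 2 to compound 4 (within the scatter)) on one core and (a 2.0-fold higher number from compound 1 to compound 3 (0.30 log units; within the scatter)) on the other, and both steps lie within the scatter, so neither core shows a real change from this swap. The series therefore gives no sign that this change, carried from one core to the other, does anything measurable in this read-out, but it does not show that the two cores respond alike, since two steps inside the scatter can support neither a shared effect nor a dependence on the core. No measurement at hand accounts for either step, so the notes offer no explanation of them.

Still open, going by these compounds, is whether a side chain carrying an amine or a carboxylic acid, placed on the same oxygen, would give a step beyond the scatter on either core. Equally open, on these data alone, is whether a longer chain, such as n-hexyl, would stay within the scatter of the cyclopentyl compounds or would separate the two cores.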